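Extending the chain on the double-bonded nitrogen

The source may report more compounds than this note shows. Statements on the series, on what has been measured and on what is new or still open speak of the compounds shown alone.

In a functional assay on OVCAR-3 cells (Homo sapiens) for antiproliferative activity, read by WST assay, with a stated time of 72 h (a higher number here means a weaker inhibitor, a lower number a stronger inhibitor), compound 1 `CCCCCCCC/N=c1\nc(N)c2ncn(Cc3ccccc3)c2c(N)n1` gives 4980 nM. Compound 2 `CC/N=c1\nc(N)c2nc[nH]c2c(N)n1` is reported in this assay as "not active" (no number reported), so no single number places it against compound 1; on the figures shown it stands only as inactive. Compound 3 `CCCCCCCC/N=c1\nc(N)c2nc[nH]c2c(N)n1` has not been measured in this assay. Compound 3 differs from compound 2 by hexyl in place of hydrogen on a saturated chain carbon, two bonds along the chain from a double-bonded nitrogen. Among the compounds with values here, no step between measured compounds is available; as compound 2 is inactive while compound 1, which differs at more than one place, sits at 4980 nM, a gain in inhibition beyond the scatter is expected, though compound 3 may also come back without a number. For compound 3 an inhibitory concentration of about 12000 nM is estimated, within 3000 nM to 50000 nM.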

Compound 3, half-maximal inhibitory concentration: "not active" (no number reported)
Compound 3: no number reported; there is nothing to compare the estimate with.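

Compound 2 and compound 3 are both reported without a number in this assay, so no step can be read between them. Left open is how far compound 1, at 4980 nM in this assay, stands from compound 3. No evidence bears on this result.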